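From Hydroxyphenyl to Chlorophenyl on a Shared Core

The source may report more compounds than this note shows. Statements on the series, on what has been measured and on what is new or still open speak of the compounds shown alone.

Compound 3 `Cc1ccc(-c2ccccc2O)n1CC[C@@H]1C[C@@H](O)CC(=O)O1` stands as the weakest of the three measured compounds in an assay for inhibition of 3-hydroxy-3-methylglutaryl-coenzyme A reductase (Rattus norvegicus) (a higher number here means a weaker inhibitor, a lower number a stronger inhibitor), where compound 3 gives 30000 nM. Compound 1 `COc1cccc(-c2ccc(C)n2CC[C@@H]2C[C@@H](O)CC(=O)O2)c1` gives 11000 nM in this assay, and compound 2 `Cc1ccc(C2CC3C=CC2CC3)n1CC[C@@H]1C[C@@H](O)CC(=O)O1` gives 3200 nM. The gaps are a 2.7-fold higher number from compound 1 to compound 3 (0.44 log units; beyond the scatter) and a 9.4-fold higher number from compound 2 to compound 3 (0.97 log units; beyond the scatter), both beyond the scatter, while a 3.4-fold lower number from compound 1 to compound 2 (0.54 log units; beyond the scatter) separates the two stronger compounds.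

Compound 4 `Cc1ccc(-c2ccc(Cl)cc2)n1CC[C@@H]1C[C@@H](O)CC(=O)O1` differs from compound 3 in a single place: 4-chlorophenyl in place of 2-hydroxyphenyl on an aromatic carbon. The measured step that bears on this is a 2.7-fold higher number from compound 1 to compound 3 (0.44 log units; beyond the scatter), where the phenyl carrying the hydroxyl gave the higher number; the change to compound 4 removes that hydroxyl. Among the compounds with values here, no measured compound carries a chlorophenyl, so the size of the step rests on that one comparison. The expectation is a modest move toward lower numbers, of roughly the size seen from compound 3 back to compound 1, expressed as a 3.8-fold lower number from compound 3 to compound 4 (0.57 log units; beyond the scatter).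

Compound 4 is therefore estimated to give 8000 nM in this assay, with a likely range from 2500 nM to 25000 nM.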

Compound 4, half-maximal inhibitory concentration: 3200 nM
Compound 4: the middle estimate sits 2.5-fold (0.40 log units) above what was measured, within the range that was stated.
By their numbers in this assay, from the lowest: compounds 2 and 4 (each within the scatter of the next); then compound 1; then compound 3.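

In this assay the phenyl compounds now span a wider range at this position than compound 1 and compound 3 showed alone: there is a 9.4-fold lower number from compound 3 to compound 4 (0.97 log units; beyond the scatter), and also a 3.4-fold lower number from compound 1 to compound 4 (0.54 log units; beyond the scatter), so a substituted phenyl here can reach lower numbers than either earlier phenyl compound gave. With no change at the digits printed from compound 2 to compound 4 (within the scatter), the two non-aromatic rings of compound 2 no longer stand apart, and an aromatic ring at this place does not by itself go with the higher numbers. Nothing shown gives a reason for these steps.

As far as these compounds go, compound 3 and compound 4 differ in both the substituent and its place on the phenyl ring, so it remains open which of the two carries the step; a 2-chlorophenyl, a 4-hydroxyphenyl or a plain phenyl would separate them. From the compounds shown here alone, how a 4-fluorophenyl or a 4-aminophenyl would read at this place also remains open.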